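The source may hold more compounds than are shown below. What is called first, only, known or untested is meant among the compounds shown, and "the series" means these compounds.

Among the measured compounds shown here, in a functional assay on OVCAR-8 cells (Homo sapiens) (on this read-out higher numbers stand for weaker inhibition of growth and lower numbers for stronger inhibition of growth), compound 3 `O=S(=O)(/C=C/c1ccc(Cl)c(Cl)c1)Cc1ccc(Nc2ncnc3ccc(Br)cc23)cc1` gives 100 nM, the lowest of the three numbers measured so far. By comparison, compound 1 `O=S(=O)(/C=C/c1ccc(Cl)c(Cl)c1)Cc1ccc(Nc2ncnc3ccccc23)cc1` gives 14000 nM, and compound 2 `O=S(=O)(/C=C/c1ccc(Br)cc1)Cc1ccc(Nc2ncnc3ccccc23)cc1` gives 38000 nM. The unmeasured compound 4 `O=S(=O)(/C=C/c1ccc(Br)cc1)Cc1ccc(Nc2ncnc3ccc(Br)cc23)cc1` differs from compound 3 by a single swap: 4-bromophenyl in place of 3,4-dichlorophenyl on a double-bonded chain carbon bound to a double-bonded chain carbon. The same swap has been measured once, as a 2.7-fold higher number from compound 1 to compound 2 (0.43 log units; beyond the scatter), a modest step beyond the scatter. The other measured step, a 140-fold lower number from compound 1 to compound 3 (2.15 log units; beyond the scatter), is large and adds the bromo group. Compound 4 keeps that bromo group, so only the swap matters here. A modest rise in this assay is therefore expected, though one pair is thin evidence. The expected change is a 2.7-fold higher number from compound 3 to compound 4 (0.43 log units; beyond the scatter). For compound 4, the estimate is 270 nM, with a range of 90 nM to 900 nM.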

Compound 4, concentration for 50% growth inhibition: 2000 nM
Compound 4: the middle estimate sits 7.4-fold (0.87 log units) below what was measured; measured number above the stated range.
By their numbers in this assay, from the lowest: compound 3; then compound 4; then compound 1; then compound 2.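

Replacing 3,4-dichlorophenyl with 4-bromophenyl has a much larger effect when the core carries the bromo group, at a 20-fold higher number from compound 3 to compound 4 (1.30 log units; beyond the scatter), so the size of this swap depends on the rest of the molecule: the same change on two cores in this assay, a 2.7-fold higher number (0.43 log units; beyond the scatter) from compound 1 to compound 2 and a 20-fold higher number (1.30 log units; beyond the scatter) from compound 3 to compound 4, 7.4-fold (0.87 log units) apart, beyond the scatter of two such steps. Seen from the other side, adding the bromo group still lowers the number in this assay with 4-bromophenyl in place, at a 19-fold lower number from compound 2 to compound 4 (1.28 log units; beyond the scatter), but by less than with 3,4-dichlorophenyl: the same change on two cores in this assay, a 140-fold lower number (2.15 log units; beyond the scatter) from compound 1 to compound 3 and a 19-fold lower number (1.28 log units; beyond the scatter) from compound 2 to compound 4, 7.4-fold (0.87 log units) apart, beyond the scatter of two such steps. In these four compounds, the two changes do not simply add up.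

On these data alone, it remains open whether a 4-chlorophenyl group would behave more like 3,4-dichlorophenyl or 4-bromophenyl. The compounds shown therefore cannot separate losing one halogen from changing chlorine to bromine.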